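A few compounds are considered here, and "the series" means these few. Any claim that something is new, unique, unknown or untested is made for them only; others in the source may bear on it.

Measured compounds:
compound 1 `FC(F)(F)c1ccc(Nc2nc(N3CCNCC3)nc3sc(Nc4c(Cl)cccc4Cl)nc23)cc1`, in a functional assay on HEK293 cells for antagonist activity at transient receptor potential cation channel subfamily V member 1 (Homo sapiens), read by calcium flux (on this read-out higher numbers stand for weaker inhibition and lower numbers for stronger inhibition), compound 1 gives 5000 nM
compound 2 `CN(C)c1nc(Nc2ccc(C(F)(F)F)cc2)c2nc(Nc3c(Cl)cccc3Cl)sc2n1`, in this assay compound 2 gives 59 nM

Within the data shown here, compound 2 holds the lower of the two numbers; the single measured step is an 85-fold lower number from compound 1 to compound 2 (1.93 log units; beyond the scatter), dimethylamino in place of piperazin-1-yl.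

Compound 3 `CC(C)CNc1nc(Nc2ccc(C(F)(F)F)cc2)c2nc(Nc3c(Cl)cccc3Cl)sc2n1` differs from compound 2 by isobutylamino in place of dimethylamino on an aromatic carbon. Among the measured compounds shown here, no measured step matches this change: the one step available exchanged piperazin-1-yl for dimethylamino, whereas here one acyclic amino group replaces another at the same carbon. It gives no direction for the present change. Compound 3 is therefore expected to stay close to compound 2, with a step of a 1.2-fold higher number from compound 2 to compound 3 (0.07 log units; within the scatter) in this assay, within the scatter. The estimate for compound 3 is 70 nM, range 20 nM to 250 nM.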

Compound 3, half-maximal inhibitory concentration: 2 nM
For compound 3 the middle estimate is 35-fold (1.54 log units) above the measured one, and the stated range ends above it.
By their numbers in this assay, from the lowest: compound 3; then compound 2; then compound 1.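

This carbon, between two ring nitrogen atoms, is sensitive even to an exchange of one acyclic amino group for another: in this assay, isobutylamino in place of dimethylamino gives a 30-fold lower number from compound 2 to compound 3 (1.47 log units; beyond the scatter). Across the position, isobutylamino in place of piperazin-1-yl gives a 2500-fold lower number from compound 1 to compound 3 (3.40 log units; beyond the scatter). No available measurement accounts for either step.

Isobutylamino differs from dimethylamino in both its chain and its hydrogen-bond donor, and these compounds do not separate the two. Open, from the compounds shown here alone, is how methylamino, or a longer chain such as pentylamino, would read at this carbon.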